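Nitro for dimethylamino: notes on a three-compound series

A few compounds are considered here, and "the series" means these few. Any claim that something is new, unique, unknown or untested is made for them only; others in the source may bear on it.

Values in a functional assay (Homo sapiens) for inhibition; a lower number here means a stronger inhibitor, a higher number a weaker inhibitor:
- compound 1 `COc1c(/C=C/C(=O)c2ccc(O)cc2)ccc(O)c1C`: 27000 nM
- compound 2 `CCCCOc1ccccc1C(=O)/C=C/c1cc(OC)cc(OC)c1`: 13000 nM
- compound 3 `COc1cc(/C=C/C(=O)c2ccccc2N(C)C)cc(OC)c1`: 5700 nM

Compound 3 holds the lowest of the three numbers, with compound 2 the nearest and compound 1 the furthest. The unmeasured compound 4 `COc1cc(/C=C/C(=O)c2ccccc2[N+](=O)[O-])cc(OC)c1` carries nitro in place of dimethylamino on an aromatic carbon. The change sits on an aromatic carbon of a six-membered aromatic ring of carbon only, ortho to a large group.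

Going by the values given here, one measured step bears on it: a 2.3-fold lower number from compound 2 to compound 3 (0.36 log units; beyond the scatter), a modest move beyond the scatter. Among the compounds with values here, no measured compound carries nitro, so that step guides the size better than the direction. A step of similar modest size is expected. Because compound 3 already stands lowest at 5700 nM, a move to a higher number is the weakly favoured expectation. The expected step is a 2.1-fold higher number from compound 3 to compound 4 (0.32 log units; beyond the scatter). For compound 4 the estimated value is 12000 nM, with an expected range of 4000 nM to 35000 nM.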

Compound 4, half-maximal inhibitory concentration: 3700 nM
Estimate against measurement, compound 4: 3.2-fold (0.51 log units) above; the whole stated range lies above it.
By their numbers in this assay, from the lowest: compounds 4 and 3 (each within the scatter of the next); then compound 2; then compound 1.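

In this assay, nitro in place of dimethylamino on this aromatic carbon gives a 1.5-fold lower number from compound 3 to compound 4 (0.19 log units; within the scatter) and so leaves the two groups unresolved at this position, although they differ in their atoms and nitro brings a double bond outside aromatic rings. Nitro in place of butoxy gives a 3.5-fold lower number from compound 2 to compound 4 (0.55 log units; beyond the scatter) and joins the earlier dimethylamino step as a second replacement of butoxy that lands beyond the scatter; among compounds 2, 3 and 4, no compound goes against this. No measurement of any property of these groups accompanies the values, and they assign no cause.

Going by these compounds, whether a primary amine, a carboxylic acid or a chain longer than butoxy fits this position remains open. Also open, on these data alone, is whether nitro gives a similar value at another carbon of this ring.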